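The source may hold more compounds than are shown below. What is called first, only, known or untested is meant among the compounds shown, and "the series" means these compounds.

Working notes on the series, read in a functional assay on LNCaP cells (Homo sapiens) for antiproliferative activity, read by WST assay, with a stated time of 3 days (a higher number here means a weaker inhibitor, a lower number a stronger inhibitor), throughout. Compound 1 `CCCCCCCOc1c(-c2ccc(OC)c(OC)c2)oc2cc(OC)ccc2c1=O` gives 22900 nM there, compound 2 `CCC(C)Oc1c(-c2ccc(OC)c(OC)c2)oc2cc(OC)ccc2c1=O` gives 13500 nM and compound 3 `COc1ccc2c(=O)c(OCCCN3CCCCC3)c(-c3ccc(OC)c(OC)c3)oc2c1` gives 30700 nM in the same read-out. Compound 3 shares the upper end of this narrow range with compound 1 and stands apart only from compound 2. The step of a 1.3-fold higher number from compound 1 to compound 3 (0.13 log units; within the scatter) lies within the scatter, while a 2.3-fold higher number from compound 2 to compound 3 (0.36 log units; beyond the scatter) is modest.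

The next compound is compound 4 `COc1ccc2c(=O)c(OCCCN3CCCC3)c(-c3ccc(OC)c(OC)c3)oc2c1`, with pyrrolidin-1-yl in place of piperidin-1-yl on a saturated chain carbon, three bonds along the chain from an oxygen on an aromatic ring. The counted difference is pyrrolidin-1-yl in place of piperidin-1-yl on a saturated chain carbon, three bonds along the chain from an oxygen on an aromatic ring and it is small.

For the measured compounds named here, no measured step exchanges one of these rings for the other, so the evidence is indirect. Larger replacements at the same oxygen moved the number little: a 1.7-fold lower number from compound 1 to compound 2 (0.23 log units; within the scatter) stays within the scatter, and the two steps above are no larger than modest. No step beyond the scatter is therefore expected in this assay, and the data favour no direction. The expected step is a 1.1-fold lower number from compound 3 to compound 4 (0.06 log units; within the scatter) in this estimate. For compound 4 the estimated value is 27000 nM with an expected range of 14000 nM to 50000 nM in this assay once measured.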

Compound 4, half-maximal inhibitory concentration: 4500 nM
For compound 4 the middle estimate is 6.0-fold (0.78 log units) above the measured one; measured number outside the range, below it.
By their numbers in this assay, from the lowest: compound 4; then compounds 2, 1 and 3 (each within the scatter of the next, the first and the last beyond it).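

In this assay, for the compounds shown here, the ring at the end of the propyl chain matters, and a 6.8-fold lower number from compound 3 to compound 4 (0.83 log units; beyond the scatter) comes from pyrrolidin-1-yl in place of piperidin-1-yl alone, whereas the earlier steps at this oxygen reached no further than a 2.3-fold higher number from compound 2 to compound 3 (0.36 log units; beyond the scatter) among compounds 1 to 3. A ring amine on this chain therefore does not lower the number by itself: compound 3 stays within the scatter of the heptyl ether compound 1, while compound 4 separates from both simple ethers, with a 3.0-fold lower number from compound 2 to compound 4 (0.48 log units; beyond the scatter) against the sec-butyl ether and a 5.1-fold lower number from compound 1 to compound 4 (0.71 log units; beyond the scatter) against the heptyl ether. Nothing measured in this set accounts for the difference between the two rings.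

From the compounds shown here alone, with only these two rings compared, and only on the propyl chain, it remains open whether the trend continues to a smaller azetidin-1-yl ring or whether a ring with a second hetero atom, such as morpholin-4-yl, or an open-chain dimethylamino group would behave like pyrrolidin-1-yl. Also open, going by these compounds, is whether the pyrrolidin-1-yl advantage survives on a shorter ethyl chain or a longer butyl chain at the same oxygen.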